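The source may hold more compounds than are shown below. What is called first, only, known or untested is meant among the compounds shown, and "the series" means these compounds.

Three compounds have been measured in a functional assay on MCF7 cells (Homo sapiens) for inhibition, read by MTT assay, with a stated time of 72 h; a higher number here means a weaker inhibitor, a lower number a stronger inhibitor:

Compound 1 `N#Cc1c(Nc2cccc(C(F)(F)F)c2)nc(SCc2cn(Cc3ccccc3Cl)nn2)nc1-c1ccccc1` gives 12600 nM.
Compound 2 `N#Cc1c(Nc2cccc(Cl)c2)nc(SCc2cn(Cc3ccccc3Cl)nn2)nc1-c1ccccc1` gives 12000 nM.
Compound 3 `COc1ccccc1Nc1nc(SCc2cn(Cc3ccccc3Cl)nn2)nc(-c2ccccc2)c1C#N` gives 6170 nM.

Going by the values given here, compound 3 shows the lowest of the three numbers in this assay, though only one of its steps is clearly resolved: the step of a 2.0-fold lower number from compound 1 to compound 3 (0.31 log units; beyond the scatter) lies beyond the scatter, while a 1.9-fold lower number from compound 2 to compound 3 (0.29 log units; within the scatter) lies within it. Compounds 1 and 2 sit close together, as a 1.1-fold lower number from compound 1 to compound 2 (0.02 log units; within the scatter) shows.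

Compound 4 `N#Cc1c(Nc2ccc(F)cc2)nc(SCc2cn(Cc3ccccc3Cl)nn2)nc1-c1ccccc1` has not yet been measured. It differs from compound 3 in one place: 4-fluorophenyl in place of 2-methoxyphenyl on a nitrogen on an aromatic ring. Among the compounds with values here, the steps that bear on this change are the two that lead into compound 3, in which the 3-(trifluoromethyl)phenyl or the 3-chlorophenyl gave way to the 2-methoxyphenyl and the number fell modestly. Compound 4 goes the other way, from the 2-methoxyphenyl back to a 4-fluorophenyl, which resembles compounds 1 and 2 more than compound 3. A modest rise in the number in this assay, back toward those of compounds 1 and 2, is therefore expected, though it may not clear the scatter. The expected step is a 1.6-fold higher number from compound 3 to compound 4 (0.21 log units; within the scatter). Compound 4 is estimated at 10000 nM in this assay, with a range from 5000 nM to 20000 nM.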

Compound 4, half-maximal inhibitory concentration: 19900 nM
Compound 4: middle estimate off by 2.0-fold (0.30 log units), on the low side; the measured number falls inside the stated range.
By their numbers in this assay, from the lowest: compounds 3, 2, 1 and 4 (each within the scatter of the next, the first and the last beyond it).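

In this assay, the change from 2-methoxyphenyl to 4-fluorophenyl on this nitrogen gives a 3.2-fold higher number from compound 3 to compound 4 (0.51 log units; beyond the scatter), so the two groups are now clearly separated at this position. The 4-fluorophenyl is not separated from the other two groups, however: a 1.7-fold higher number from compound 2 to compound 4 (0.22 log units; within the scatter) and a 1.6-fold higher number from compound 1 to compound 4 (0.20 log units; within the scatter) leave compound 4 unresolved from both compound 2 and compound 1, and the 3-chlorophenyl, 3-(trifluoromethyl)phenyl and 4-fluorophenyl groups cannot be ordered among themselves. The 2-methoxyphenyl of compound 3 is thus resolved from the 4-fluorophenyl and the 3-(trifluoromethyl)phenyl but not from the 3-chlorophenyl, and no measurement is available that would explain this difference.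

The compounds shown leave open whether the lower number of compound 3 belongs to the methoxy group itself or to where it sits on the ring, since the methoxy group appears in only one compound here. They also leave open how a plain phenyl, a pyridyl ring or a benzyl group on this nitrogen would read in this assay.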